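A Benzyloxy Group Added to an Oxime Series

This account rests on a few compounds, and the source may have more. Where it says the series, first, only, none or still open, it means among the compounds named here.

Measured compounds:
compound 1 `O/N=C(\CCN1CCN(c2ccccn2)CC1)c1cccc(F)c1` — 72%
compound 2 `Cc1cccc(/C(CCN2CCN(c3ccccn3)CC2)=N/O)c1` — 74%
compound 3 `O/N=C(\CCN1CCN(c2ccccn2)CC1)c1cc(F)cc(F)c1` — 74%

In a functional assay on HEK293 cells with D(4) dopamine receptor (Homo sapiens) as the target, read by FLIPR (on this read-out lower numbers stand for smaller maximal responses and higher numbers for larger maximal responses), compound 1 gives 72%, compound 2 gives 74% and compound 3 gives 74%. Compound 2 stands level with compound 3 at the digits shown, and the step of a number 2 percentage points higher from compound 1 to compound 2 (within the scatter) is small, as is no change at the digits printed from compound 2 to compound 3 (within the scatter). Compound 4 `Cc1ccc(OCc2ccccc2)c(/C(CCN2CCN(c3ccccn3)CC2)=N/O)c1` differs from compound 2 in one place: benzyloxy in place of hydrogen on an aromatic carbon. The measured steps all swapped small groups on the aromatic ring and none moved the response beyond the scatter, so they offer only a weak guide to a change of this size. Compound 4 is therefore expected near compound 2, with the step of a number 8 percentage points lower from compound 2 to compound 4 (within the scatter) estimated as a modest drop and a wide range, giving 66% between 45% and 85%.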

Compound 4, largest response reached (reported as efficacy), in percent of the reference or control that the assay uses: 4%
The estimate for compound 4 lay 62 percentage points above the measured number; the whole stated range lies above it.
By their numbers in this assay, from the lowest: compound 4; then compounds 1, 2 and 3 (each within the scatter of the next).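

Among compounds 1, 2 and 3, small swaps on the aromatic ring left the response within the scatter, but in this assay adding benzyloxy on this aromatic carbon, ortho to a large group and para to a methyl group, gives a number 70 percentage points lower from compound 2 to compound 4 (beyond the scatter). This position is therefore not indifferent to what it carries: this one addition almost abolishes the response. Nothing available here accounts for the drop. The compounds shown leave open whether a smaller group here, such as methoxy or hydroxy, would keep the response, and whether the loss follows the oxygen link or the added ring.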